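Silyl ether analogues in a cytotoxicity series

The compounds below may be only part of what the source reports. "The series", "measured", "known", "first", "only" and "open" are said of these compounds alone.

Measured compounds:
compound 1 `COc1ccc(C2=C(c3cc(OC)c(OC)c(OC)c3)C(=O)CC2O[SiH2]C(C)(C)C)cc1OC` > 100 ug/mL
compound 2 `COc1ccc(C2=C(c3cc(OC)c(OC)c(OC)c3)CC(O)C2=O)cc1N` < 1 ug/mL

Of the compounds shown here, two have been tested in an ADME assay on KB cells (Homo sapiens) for cytotoxicity, read by MTT assay, with a stated time of 72 h; a lower number here means a stronger inhibitor, a higher number a weaker inhibitor. Compound 1 reaches only the upper limit of this assay, (the limit of > 100 ug/mL in this assay, at which 1 of the 2 values shown sits). Compound 2, by contrast, sits at the lower limit, (the limit of < 1 ug/mL in this assay, at which 1 of the 2 values shown sits). Compound 1 therefore stands as the weaker of the two, with no number of its own. Compound 3 `COc1cc(C2=C(c3cc(C)c(OC)c(C)c3)C(O[SiH2]C(C)(C)C)CC2=O)cc(OC)c1OC` follows compound 1 with one change: 4-methoxy-3,5-dimethylphenyl in place of 3,4-dimethoxyphenyl on a double-bonded ring carbon. Among the measured compounds shown here, no step between measured compounds guides this change, so the account expects the step of a number no higher from compound 1 to compound 3 (the limit leaves the size open) to stay within the scatter. Compound 3 is estimated at 100 ug/mL, between 30 ug/mL and 300 ug/mL.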

Compound 3, half-maximal inhibitory concentration: 40 ug/mL
Compound 3: middle estimate off by 2.5-fold (0.40 log units), on the high side; measured number inside the range.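

In this assay, 4-methoxy-3,5-dimethylphenyl in place of 3,4-dimethoxyphenyl on a double-bonded ring carbon gives an at least 2.5-fold lower number from compound 1 to compound 3 (0.39 log units; beyond the scatter). For compound 1, the value > 100 ug/mL is a limit of the assay, not a number. Compound 3 thus shows that, with the silyl ether kept, the read-out responds to a change at this position, which compounds 1 and 2 alone could not show.

On these data alone, whether a carboxylic acid or a nitrile on this phenyl ring would shift the number further remains open. The compounds shown also do not say why this change lowers it.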